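The source may hold more compounds than are shown below. What is called first, only, known or untested is meant among the compounds shown, and "the series" means these compounds.

Compound 1 `CCOC(=O)c1c(-c2cccc(OC)c2)[nH]c2cc(OC)ccc2c1=O`: > 22000 nM
Compound 2 `CCOC(=O)c1c(-c2cccc(OC)c2)[nH]c2cc(Cl)c(Cl)cc2c1=O`: > 22000 nM
Compound 3 `CCOC(=O)c1c(-c2cccc(-c3ccccc3)c2)[nH]c2cc(OC)c(Cl)cc2c1=O`: > 22000 nM

All of these results come from an ADME assay on HEK293 cells (Homo sapiens) for cytotoxicity, read by luminescence, with a stated time of 72 h (a higher number here means that more compound is needed for the effect, a lower number that less compound is needed), and none of them is an exact number. In this test, compound 3 gives > 22000 nM, which is a limit of the assay. The other two compounds offer no number to compare it with, and the whole set stands at the limit of > 22000 nM in this assay, at which 3 of the 3 values shown sit.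

Compound 4 `CCOC(=O)c1c(-c2cccc(OC)c2)[nH]c2cc(OC)c(Cl)cc2c1=O` has not yet been measured. It differs from compound 3 in one place: methoxy in place of phenyl on an aromatic carbon, on a six-membered aromatic ring of carbon only, meta to a large group (methoxy in place of phenyl on an aromatic carbon).

For the measured compounds named here, no step between measured compounds is available, so the expectation rests on the compounds that already carry this methoxy. Compound 1 has it and gives > 22000 nM, again a limit. Compound 2 has it too and gives > 22000 nM, also a limit. Compound 3, with phenyl instead, sits at the same limit, so no step beyond the scatter is expected in this assay. The expected change is a number no higher from compound 3 to compound 4 (the limit leaves the size open). Most likely the result will again be a limit rather than a number. The estimate for compound 4 is 22000 nM, with an expected range from 14000 nM to 30000 nM.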

Compound 4, half-maximal effective concentration: > 22000 nM
Compound 4 ended at the assay's limit; the forecaster's own chance of this, stated with the estimate: 90%; the middle value lies on the limit itself.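

In this assay compound 4 gives > 22000 nM, which is a limit of the assay. Its steps from compound 1, compound 2 and compound 3 cannot be read, with every value at a limit: the limit of > 22000 nM in this assay, at which 4 of the 4 values shown sit. The compounds shown leave open how much of each would be needed for the effect, and whether swapping these groups changes that amount.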